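From Acetyl to 4-Bromophenyl: An Untested Step

The source may hold more compounds than are shown below. What is called first, only, known or untested is meant among the compounds shown, and "the series" means these compounds.

Compound 1 `CC(=O)c1cc2ccc(OCCCn3cc(CNC(=O)CCCCC4CCSS4)nn3)cc2oc1=O` was measured in a functional assay on PC-12 cells (Rattus norvegicus) for cytotoxicity, read by MTT assay, with stated times of 3 h and 2 h, tested at 10 uM (a lower number here means a weaker effect, a higher number a stronger effect of the compound at the concentration tested), where compound 1 gives 38%. Among the three measured compounds this places compound 1 second highest. Compound 2 `CCOC(=O)c1cc2ccc(OCCCn3cc(CNC(=O)CCCCC4CCSS4)nn3)cc2oc1=O` gives 36.1%, and the step of a number 1.9 percentage points lower from compound 1 to compound 2 (within the scatter) lies within the scatter. Compound 3 `O=C(CCCCC1CCSS1)NCc1cn(CCCOc2ccc3cc(C(=O)O)c(=O)oc3c2)nn1` gives 59.9%, reached by the step of a number 21.9 percentage points higher from compound 1 to compound 3 (beyond the scatter); the step of a number 23.8 percentage points higher from compound 2 to compound 3 (beyond the scatter) is of similar size.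

Compound 4 `O=C(CCCCC1CCSS1)NCc1cn(CCCOc2ccc3cc(-c4ccc(Br)cc4)c(=O)oc3c2)nn1` differs from compound 1 at one place: 4-bromophenyl in place of acetyl on an aromatic carbon. Within the data shown here, none of the measured steps removes the acetyl as a whole. The step of a number 1.9 percentage points lower from compound 1 to compound 2 (within the scatter) shows that putting ethoxy in place of methyl on the carbonyl carbon changes little, while the step of a number 21.9 percentage points higher from compound 1 to compound 3 (beyond the scatter) shows that a hydroxy on the carbonyl carbon raises the number. Compound 4 carries neither a carbonyl nor a hydroxy at that position, so no step beyond the scatter is expected in this assay. Compound 4 is therefore estimated at 40%, with a range from 25% to 56%, which means an expected step of a number 2 percentage points higher from compound 1 to compound 4 (within the scatter).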

Compound 4, a percentage reported as activity, at one concentration (the size of the read-out at that concentration, not a potency): 63.3%
Compound 4: middle estimate off by 23.3 percentage points, on the low side; the measured number lies above the stated range.
By their numbers in this assay, from the lowest: compounds 2 and 1 (each within the scatter of the next); then compounds 3 and 4 (each within the scatter of the next).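

At this aromatic carbon, the acetyl can be replaced as a whole by 4-bromophenyl, which brings a six-membered aromatic ring and a bromine and has no hydrogen-bond acceptor, and this assay shows a number 25.3 percentage points higher from compound 1 to compound 4 (beyond the scatter) and also a number 27.2 percentage points higher from compound 2 to compound 4 (beyond the scatter). Among these compounds, the carboxy of compound 3 is thus no longer the only group at this place that separates a compound from compounds 1 and 2, for a number 3.4 percentage points higher from compound 3 to compound 4 (within the scatter) leaves the two groups within the scatter of each other. Nothing shown here gives a reason for this rise.

The compounds shown cannot tell whether the higher number goes with the aromatic ring or with the bromine, a question that plain phenyl in the same place would address. On these data alone, how an amine on that phenyl ring, or a longer chain in its place, would read also remains open.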